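The source may report more compounds than this note shows. Statements on the series, on what has been measured and on what is new or still open speak of the compounds shown alone.

In a functional assay on U-251 cells (Homo sapiens) for antiproliferative activity, read by MTT assay, with a stated time of 48 h (on this read-out higher numbers stand for weaker inhibition and lower numbers for stronger inhibition), compound 1 `COc1ccc(-c2nc3cccc(-c4cc(OC)c(OC)c(OC)c4)c3o2)cc1OC` gives 1300 nM, compound 2 `COc1ccc(-c2nc3cccc(-c4cc(OC)c(OC)c(OC)c4)c3o2)cc1F` gives 1700 nM and compound 3 `COc1cc(-c2cccc3nc(-c4ccc(Cl)cc4)oc23)cc(OC)c1OC` gives 1600 nM. All three lie within the scatter of one another, so compound 3 holds no distinct place among them. Compound 4 `COc1cc(-c2cccc3nc(-c4cccc(C)c4)oc23)cc(OC)c1OC` carries 3-methylphenyl in place of 4-chlorophenyl on an aromatic carbon. Two measured swaps at that same place stayed within the scatter (a 1.2-fold higher number from compound 1 to compound 3 (0.09 log units; within the scatter) and a 1.1-fold lower number from compound 2 to compound 3 (0.03 log units; within the scatter)). Fluoro in place of methoxy also stayed within it (a 1.3-fold higher number from compound 1 to compound 2 (0.12 log units; within the scatter)). No step beyond the scatter is therefore expected in this assay (expected step: no change at the digits printed from compound 3 to compound 4 (within the scatter)). For compound 4 the estimated value is 1600 nM (estimated range: 750 nM to 3400 nM).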

Compound 4, half-maximal inhibitory concentration: > 25000 nM
Compound 4: no number, only a limit; the forecaster's own chance of this, stated with the estimate: 3%; at least 15-fold (1.19 log units) between middle value and limit.
By their numbers in this assay, from the lowest: compounds 1, 3 and 2 (each within the scatter of the next). At a limit, above all of these: compound 4.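

Compound 4 gives no number, only a limit: the limit of > 25000 nM in this assay, at which 1 of the 4 values shown sits. In this assay this position is therefore not indifferent to its aryl group, as 3-methylphenyl gives an at least 15-fold higher number from compound 3 to compound 4 (1.19 log units; beyond the scatter), an at least 14-fold higher number from compound 2 to compound 4 (1.16 log units; beyond the scatter) and an at least 19-fold higher number from compound 1 to compound 4 (1.28 log units; beyond the scatter). Within the data shown here, the earlier swaps among 4-chlorophenyl, 3-fluoro-4-methoxyphenyl and 3,4-dimethoxyphenyl showed no such step.

The compounds shown do not separate the loss of chlorine from the entry of methyl, nor the placing of the substituent on the phenyl ring from its kind. Going by these compounds, how a 4-methylphenyl, or a phenyl bearing an amine or a carboxylic acid, would read here remains open.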